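Swapping cyclohexyl for tert-butyl on the shared core

The source may hold more compounds than are shown below. What is called first, only, known or untested is meant among the compounds shown, and "the series" means these compounds.

- compound 1 `CC(C)c1cc(C(O)CC2CCCCN2)c2ccccc2n1` at 1.58
- compound 2 `OC(CC1CCCCN1)c1cc(C2CCCCC2)nc2ccccc12` at 2.56

In a physicochemical assay for lipophilicity (a lower number here means a more polar compound, a higher number a more lipophilic compound), compound 2 is the higher of the two at 2.56 with compound 1 lower. Among the measured compounds shown here, compound 3 `CC(C)(C)c1cc(C(O)CC2CCCCN2)c2ccccc2n1` differs from compound 2 in one place, with tert-butyl in place of cyclohexyl on an aromatic carbon as the only change. For the measured compounds named here, one measured step bears on this, a modest rise beyond the scatter when cyclohexyl took the place of isopropyl. Tert-butyl, like isopropyl, has no ring, so a good part of a number 0.98 log units higher from compound 1 to compound 2 (beyond the scatter) is expected to reverse here. The estimated step is a fall, a number 0.61 log units lower from compound 2 to compound 3 (beyond the scatter) in all. For compound 3 the expected value is 1.95 with an estimated range from 1.55 to 2.35 around it.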

Compound 3, partition coefficient: 2.03
Estimate against measurement, compound 3: 0.08 log units below; the measured number falls inside the stated range.
By their numbers in this assay, from the lowest: compound 1; then compound 3; then compound 2.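

In this assay, the step of a number 0.53 log units lower from compound 2 to compound 3 (beyond the scatter) shows that replacing cyclohexyl with the smaller, ring-free tert-butyl undoes part of the earlier rise, while a number 0.45 log units higher from compound 1 to compound 3 (beyond the scatter) shows that one added methyl on the isopropyl group also gives a change beyond the scatter. Compound 3 therefore lies between the other two, so even small all-carbon changes at this position shift the number. Nothing measured here gives a cause for these shifts.

All three groups contain only carbon and hydrogen. From the compounds shown here alone, how a methoxy group, an amine or a carboxylic acid at this position would compare remains open.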